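Adding a chloro group to the pyrimidinyl amine

The compounds below may be only part of what the source reports. "The series", "measured", "known", "first", "only" and "open" are said of these compounds alone.

Three compounds share one core and differ only in the ring attached to the amine nitrogen. Compound 1 `C[C@@H](Cn1ccc(-c2ccc(C#N)c(Cl)c2)n1)Nc1ccccc1` carries a phenyl there, and in a functional assay on LNCaP cells (Homo sapiens) for antiproliferative activity, read by CCK-8 assay, with a stated time of 6 days (on this read-out lower numbers stand for stronger inhibition and higher numbers for weaker inhibition), compound 1 gives 710 nM. Compound 2 `C[C@@H](Cn1ccc(-c2ccc(C#N)c(Cl)c2)n1)Nc1ccccn1` carries pyridin-2-yl, and in this assay compound 2 gives 1110 nM. Compound 3 `C[C@@H](Cn1ccc(-c2ccc(C#N)c(Cl)c2)n1)Nc1ncccn1` carries pyrimidin-2-yl, and in this assay compound 3 gives 1180 nM, the highest of the three numbers; still, the steps of a 1.6-fold higher number from compound 1 to compound 2 (0.19 log units; within the scatter), a 1.7-fold higher number from compound 1 to compound 3 (0.22 log units; within the scatter) and a 1.1-fold higher number from compound 2 to compound 3 (0.03 log units; within the scatter) all lie within the scatter, so the three compounds cannot be ranked. Compound 4 `C[C@@H](Cn1ccc(-c2ccc(C#N)c(Cl)c2)n1)Nc1nccc(Cl)n1` differs from compound 3 by chloro in place of hydrogen on an aromatic carbon. For the measured compounds named here, none of the measured steps adds a group to this ring; each only swaps the ring itself, and each stayed within the scatter. Going by the values given here, no measured step speaks directly to this change. Compound 4 is therefore expected, with wide uncertainty, to give about 1000 nM, between 350 nM and 3000 nM. The expected step of a 1.2-fold lower number from compound 3 to compound 4 (0.07 log units; within the scatter) is thus small, in no set direction.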

Compound 4, half-maximal inhibitory concentration: 1400 nM
Estimate against measurement, compound 4: 1.4-fold (0.15 log units) below; measured number inside the range.
By their numbers in this assay, from the lowest: compounds 1, 2, 3 and 4 (each within the scatter of the next).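

In this assay, putting a chloro group on the pyrimidin-2-yl ring, on the aromatic carbon next to the ring nitrogen, gives a 1.2-fold higher number from compound 3 to compound 4 (0.07 log units; within the scatter) and so adds a chlorine atom to this ring with no change that can be told from the scatter. The comparisons with the other rings read the same way, with a 1.3-fold higher number from compound 2 to compound 4 (0.10 log units; within the scatter) and a 2.0-fold higher number from compound 1 to compound 4 (0.29 log units; within the scatter), so the four groups on the amine nitrogen still cannot be ranked. No measurement of any property of the chloro group or of the compounds bears on this result.

Going by these compounds, whether an amine or a methoxy group on this same carbon would move the number beyond the scatter remains open. So does the outcome of a chloro group on another carbon of the ring.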